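This account rests on a few compounds, and the source may have more. Where it says the series, first, only, none or still open, it means among the compounds named here.

Measured compounds in this series:

Compound 1, `O=C(Nc1ccncn1)c1cc2c(OCC[C@@H]3CCCCN3)c(-c3cc(Cl)cc(Cl)c3)c(O)nc2cc1Cl`: 1.1 nM
Compound 2, `Cc1cc(-c2c(O)nc3cc(Cl)c(C(=O)Nc4ccncn4)cc3c2OCC[C@@H]2CCCCN2)cc(C)c1C`: 0.3 nM
Compound 3, `Cc1cc(C)cc(-c2c(O)nc3cc(Cl)c(NC(=O)c4cnccn4)cc3c2OCC[C@@H]2CCCCN2)c1`: 2 nM

All three numbers come from an assay on isolated protein for inhibition of Gonadotropin-releasing hormone receptor (Homo sapiens); a higher number here means a weaker inhibitor, a lower number a stronger inhibitor. Compound 1 holds the second highest of the three numbers. Its nearest neighbour is compound 3, whose value sits within the scatter of compound 1, so no order between them is claimed. Compound 2 is furthest off: the step of a 3.7-fold lower number from compound 1 to compound 2 (0.56 log units; beyond the scatter) is beyond the scatter, and it comes from a single change in the aryl group on the shared core.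

Compound 4, `O=C(Nc1ccncn1)c1cc2c(OCC[C@@H]3CCCCN3)c(-c3ccc(Cl)c(Cl)c3)c(O)nc2cc1Cl`, has not been measured. Against compound 1 the change is 3,4-dichlorophenyl in place of 3,5-dichlorophenyl on an aromatic carbon. The two compounds have the same atoms joined differently; only the pattern of the two chlorine atoms on the aryl ring moves.

Within the data shown here, the step from compound 1 to compound 2 is the only measured change at this aryl position, and it is modest even when the ring is replaced wholesale. Compound 3 carries a different aryl group and a different amide, so its comparison with compound 2 is not a single step and is read only as two values lying close together. Nothing measured separates one dichloro pattern from another. The expectation for compound 4 is therefore a step of a 1.3-fold higher number from compound 1 to compound 4 (0.10 log units; within the scatter) that stays within the scatter, with no clear direction. The estimate for compound 4 is 1.4 nM, spanning 0.5 nM to 4.5 nM.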

Compound 4, half-maximal inhibitory concentration: 1 nM
For compound 4 the middle estimate is 1.4-fold (0.15 log units) above the measured one; measured number inside the range.
By their numbers in this assay, from the lowest: compound 2; then compounds 4, 1 and 3 (each within the scatter of the next).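

In this assay, among these compounds, moving one chlorine on the aryl ring gives a 1.1-fold lower number from compound 1 to compound 4 (0.04 log units; within the scatter) and so provides the first direct comparison of two dichloro patterns at this position; the 3,4-dichlorophenyl and 3,5-dichlorophenyl groups are not separated by this measurement. The other new comparison, a 3.3-fold higher number from compound 2 to compound 4 (0.52 log units; beyond the scatter) in this assay, places the 3,4,5-trimethylphenyl group apart from a second dichlorophenyl pattern as well as from the 3,5-dichlorophenyl group, so the earlier gap at this position is not confined to a single chlorine arrangement. No supporting measurement is available to account for either step.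

The compounds shown do not separate the effect of exchanging methyl for chlorine from the effect of adding a third ring substituent, and a 3,4-dimethylphenyl or 3,4,5-trichlorophenyl group on the core of compound 4 would address that question. From the compounds shown here alone, the tolerance of this position to other ring patterns also remains open, including an unsubstituted phenyl, a 2,3-dichlorophenyl group, or a ring carrying a methoxy group.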